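The source may hold more compounds than are shown below. What is called first, only, known or untested is meant among the compounds shown, and "the series" means these compounds.

Values in a functional assay on A549 cells (Homo sapiens) for antiproliferative activity, read by MTT assay, with a stated time of 24 h; a lower number here means a stronger inhibitor, a higher number a weaker inhibitor:

compound 1 `O=C(NNc1cccc(Cl)c1)c1ccc(NS(=O)(=O)c2cnc(O)nc2O)cc1` gives 7290 nM
compound 2 `Cc1ccccc1NNC(=O)c1cccc(NS(=O)(=O)c2cnc(O)nc2O)c1` gives 14200 nM
compound 3 `O=C(NNc1ccccc1Cl)c1cccc(NS(=O)(=O)c2cnc(O)nc2O)c1` gives 1460 nM

Of these three, compound 3 has the lowest number, and the values of compound 1 and compound 2 both lie above it by more than the usual scatter. Compound 4 `O=C(NNc1ccccc1F)c1cccc(NS(=O)(=O)c2cnc(O)nc2O)c1` has not yet been measured. It departs from compound 3 by one exchange, fluoro in place of chloro on an aromatic carbon, ortho to a large group (fluoro in place of chloro on an aromatic carbon), so that 2-chlorophenyl becomes 2-fluorophenyl.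

For the measured compounds named here, one measured step bears on this place: a 9.7-fold lower number from compound 2 to compound 3 (0.99 log units; beyond the scatter), a modest step beyond the scatter that came with chloro in place of methyl on an aromatic carbon. Compound 1 differs from the others in more than one place, so only its value can be set beside theirs. Going by the values given here, no measured compound carries fluoro, so the direction cannot be read directly. Since compound 3 already stands lowest at 1460 nM, a rise is judged likelier than a further fall. The expected change is smaller than the measured one, and the estimate is a 1.9-fold higher number from compound 3 to compound 4 (0.28 log units; within the scatter) in this assay overall. Compound 4 is estimated at 2800 nM, with 900 nM to 9000 nM as the expected range.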

Compound 4, half-maximal inhibitory concentration: 11100 nM
Compound 4: middle estimate off by 4.0-fold (0.60 log units), on the low side; the whole stated range lies below it.
By their numbers in this assay, from the lowest: compound 3; then compounds 1, 4 and 2 (each within the scatter of the next).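

In this assay the chloro of compound 3 proves not to be interchangeable with fluoro on this aromatic carbon, ortho to a large group: the exchange gives a 7.6-fold higher number from compound 3 to compound 4 (0.88 log units; beyond the scatter) and so runs opposite to a 9.7-fold lower number from compound 2 to compound 3 (0.99 log units; beyond the scatter) in the earlier data. Fluoro and methyl at this place do not separate, with a 1.3-fold lower number from compound 2 to compound 4 (0.11 log units; within the scatter) as the step between them, so among the three groups tried here only chloro stands apart, and the low number of compound 3 belongs to the 2-chlorophenyl group and not to any substituent at this place. No measurement is at hand that accounts for why chloro differs from fluoro and methyl here.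

The compounds shown leave open whether bromo, methoxy or trifluoromethyl on this carbon would read with chloro or with fluoro and methyl. Compound 1 also carries chloro but differs in more than one place, so it cannot tell whether the standing of chloro depends on this particular place on the ring.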